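Swapping the Amine Group: From Compound 2 to Compound 3

The source may report more compounds than this note shows. Statements on the series, on what has been measured and on what is new or still open speak of the compounds shown alone.

Compound 1 `CC(C(=O)NCc1ccc(C(F)(F)F)nc1N(C)C)c1ccc(NS(C)(=O)=O)c(F)c1` and compound 2 `CC1CCCN1c1nc(C(F)(F)F)ccc1CNC(=O)[C@@H](C)c1ccc(NS(C)(=O)=O)c(F)c1` share one core and differ in the amine group attached to the six-membered aromatic ring with one nitrogen. In a functional assay on CHO-K1 cells for antagonist activity at transient receptor potential cation channel subfamily V member 1 (Homo sapiens), read by FLIPR (on this read-out higher numbers stand for weaker inhibition and lower numbers for stronger inhibition), compound 1 gives 19.1 nM, while compound 2 gives 0.3 nM, the lower of the two numbers and beyond the scatter from compound 1. Compound 3 `C[C@H](C(=O)NCc1ccc(C(F)(F)F)nc1N1CCC(c2ccccc2)CC1)c1ccc(NS(C)(=O)=O)c(F)c1` carries the change (4-phenylpiperidin-1-yl in place of 2-methylpyrrolidin-1-yl on an aromatic carbon). Going by the values given here, no measured pair shows a step of this kind, so its size is uncertain; a modest weakening is expected. For compound 3 the estimate in this assay is 3 nM, with a range from 0.5 nM to 30 nM. The expected step is a 10-fold higher number from compound 2 to compound 3 (1.00 log units; beyond the scatter).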

Compound 3, inhibition constant: 0.3 nM
For compound 3 the middle estimate is 10-fold (1.00 log units) above the measured one, outside the stated range (below it).
By their numbers in this assay, from the lowest: compounds 2 and 3 (each within the scatter of the next); then compound 1.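

In this assay the move to 4-phenylpiperidin-1-yl in place of 2-methylpyrrolidin-1-yl gives no change at the digits printed from compound 2 to compound 3 (within the scatter) and so shows that this position, on an aromatic carbon next to the ring nitrogen, tolerates a much larger amine group. The added six-membered aromatic ring of carbon only costs nothing measurable on this read-out. No evidence at hand explains this tolerance. The compounds shown leave open whether the position would hold up equally with a carboxylic acid or a primary amine in place of the phenyl on the piperidine.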